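Pyridylmethyl to piperidinyl swap on the terminal amine

This account rests on a few compounds, and the source may have more. Where it says the series, first, only, none or still open, it means among the compounds named here.

Compound 1 `c1cncc(CNCCCCN(C[C@H]2Cc3ccccc3CN2)[C@H]2CCCc3cccnc32)c1` gives the lowest of the three numbers shown in a functional assay on cells for antagonist activity at C-X-C chemokine receptor type 4 (Homo sapiens), read by fluorescence and calcium flux, with stated times of 25 min and 90 s (a higher number here means a weaker inhibitor, a lower number a stronger inhibitor), at 15.3 nM; compound 2 `O=S1(=O)CCC(CNCCCCN(C[C@H]2Cc3ccccc3CN2)[C@H]2CCCc3cccnc32)CC1` gives 17 nM and compound 3 `c1ccc2c(c1)CN[C@@H](CN(CCCCNC1CCOCC1)[C@H]1CCCc3cccnc31)C2` gives 29.4 nM, both within the scatter of compound 1. Compound 4 `c1ccc2c(c1)CN[C@@H](CN(CCCCNC1CCNCC1)[C@H]1CCCc3cccnc31)C2` has not been measured. Its change from compound 1 is piperidin-4-yl in place of (pyridin-3-yl)methyl on an amine nitrogen. The nearest measured step is a 1.9-fold higher number from compound 1 to compound 3 (0.28 log units; within the scatter), where a saturated six-membered ring also replaced the (pyridin-3-yl)methyl group; a 1.7-fold higher number from compound 2 to compound 3 (0.24 log units; within the scatter) and a 1.1-fold higher number from compound 1 to compound 2 (0.05 log units; within the scatter) were likewise within the scatter. No step beyond the scatter is therefore expected for a 1.4-fold higher number from compound 1 to compound 4 (0.16 log units; within the scatter). Compound 4 is expected to give about 22 nM in this assay, with a range of 8 nM to 60 nM.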

Compound 4, half-maximal inhibitory concentration: 63.4 nM
The estimate for compound 4 lay 2.9-fold (0.46 log units) below the measured number, outside the stated range (above it).
By their numbers in this assay, from the lowest: compounds 1, 2 and 3 (each within the scatter of the next); then compound 4.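

In this assay the terminal amine position does not treat all saturated six-membered rings alike: piperidin-4-yl in place of oxan-4-yl is a step beyond the scatter (a 2.2-fold higher number from compound 3 to compound 4 (0.33 log units; beyond the scatter)), whereas the steps among compounds 1, 2 and 3 all stayed within it. Piperidin-4-yl also stands beyond the scatter against the other two groups (a 4.1-fold higher number from compound 1 to compound 4 (0.62 log units; beyond the scatter); a 3.7-fold higher number from compound 2 to compound 4 (0.57 log units; beyond the scatter)). No evidence here explains this difference.

Still open, on these data alone, is whether 1-methylpiperidin-4-yl or (piperidin-4-yl)methyl on this amine nitrogen would give numbers nearer those of compound 1 or compound 4.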